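A few compounds are considered here, and "the series" means these few. Any claim that something is new, unique, unknown or untested is made for them only; others in the source may bear on it.

Working notes on the series, all read in a functional assay on HCT-116 cells (Homo sapiens) for inhibition, read by MTT assay, with a stated time of 72 h; on this read-out lower numbers stand for stronger inhibition and higher numbers for weaker inhibition. Compound 1 (`Nc1ccccc1NC(=O)c1ccc(CNCc2nc(-c3ccc(Cl)cc3)no2)cc1`) gives 6810 nM. Compound 2 (`O=C(NO)c1ccc(CNCc2nc(-c3ccccc3)no2)cc1`) gives 29300 nM, and compound 3 (`O=C(NO)c1ccc(CNCc2nc(-c3ccc(C(F)(F)F)cc3)no2)cc1`) gives 43100 nM. Compound 3 therefore stands within the scatter of compound 2, while compound 1 shows a lower number, beyond the scatter from compound 3.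

The change under review leads to compound 4 (`O=C(NO)c1ccc(CNCc2nc(-c3ccc(Cl)cc3)no2)cc1`): chloro in place of trifluoromethyl on an aromatic carbon. In words, this is chloro in place of trifluoromethyl on an aromatic carbon, para to a large group.

Within the data shown here, one measured step bears directly on this carbon. Trifluoromethyl in place of hydrogen gave a 1.5-fold higher number from compound 2 to compound 3 (0.17 log units; within the scatter), so that exchange stayed within the scatter. Among the measured compounds shown here, compound 1 carries chloro as well, but it also differs from compound 4 elsewhere, so no measured step isolates chloro. The data hold no direct comparison of chloro with trifluoromethyl.

On this basis, no change beyond the scatter is expected in this assay, in either direction. The expected shift is small, an estimated 1.3-fold lower number from compound 3 to compound 4 (0.12 log units; within the scatter). For compound 4 the estimate is 33000 nM, with an expected range of 15000 nM to 65000 nM.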

Compound 4, half-maximal inhibitory concentration: 30200 nM
Compound 4: the middle estimate sits 1.1-fold (0.04 log units) above what was measured; low and high end bracket the measured number.
By their numbers in this assay, from the lowest: compound 1; then compounds 2, 4 and 3 (each within the scatter of the next).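

In this assay, the direct exchange of trifluoromethyl for chloro on this aromatic carbon (a 1.4-fold lower number from compound 3 to compound 4 (0.15 log units; within the scatter)) and the exchange of hydrogen for chloro on the same carbon (a 1.0-fold higher number from compound 2 to compound 4 (0.01 log units; within the scatter)) both stay within the scatter, so hydrogen, trifluoromethyl and chloro, para to a large group, are not told apart by compound 2, compound 3 and compound 4. Among these compounds, with chloro held constant, compound 4 also gives the first single-place comparison for the amide-type nitrogen, hydroxy in place of 2-aminophenyl (a 4.4-fold higher number from compound 1 to compound 4 (0.65 log units; beyond the scatter)), a modest step but beyond the scatter, so in this small set the nitrogen substituent separates the numbers while this aromatic carbon does not. No measured evidence bears on why either result comes out as it does.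

The compounds shown leave open whether a group of another kind on this aromatic carbon, such as an amine or a carboxylic acid, would move the number beyond the scatter. They also leave open whether 2-aminophenyl on the amide-type nitrogen would keep its separation with hydrogen or trifluoromethyl on this carbon, since compound 1 alone carries it.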